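The source may hold more compounds than are shown below. What is called first, only, known or untested is meant among the compounds shown, and "the series" means these compounds.

Working notes on the series, read in an ADME assay on microsomes from liver (Homo sapiens) for metabolic stability; a higher number here means faster removal of the compound, a lower number slower removal. Within the data shown here, compound 1 (`COc1ccc([C@H](C)NC(=O)Cn2nnc3ccccc3c2=O)cc1`) gives 13 mL/min/kg, the lower of the two numeric values so far. Compound 3 (`Cc1ccc([C@H](C)NC(=O)Cn2nnc3ccccc3c2=O)c(F)c1`) gives 28 mL/min/kg. Compound 2 (`Cc1ccc([C@H](C)NC(=O)Cn2nnc3ccccc3c2=O)cn1`) returns only a limit of the assay, < 9.9 mL/min/kg.

Next to be read is compound 4 (`C[C@H](NC(=O)Cn1nnc2ccccc2c1=O)c1ccc(OC(F)F)cc1`). Its change from compound 1 is difluoromethyl in place of methyl on an oxygen on an aromatic ring, or methoxy to difluoromethoxy.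

Among the measured compounds shown here, no measured step makes this exact change. The nearest evidence comes from two steps that replace the whole aromatic group carrying the methoxy. One is an at least 1.3-fold lower number from compound 1 to compound 2 (0.11 log units; that floor lies within the scatter), and the other is a 2.2-fold higher number from compound 1 to compound 3 (0.33 log units; beyond the scatter). The remaining comparison, an at least 2.8-fold higher number from compound 2 to compound 3 (0.45 log units; beyond the scatter), does not involve compound 1 but shows how far the number moves between such groups. Those replacements are much larger than the edit in compound 4, yet compound 3 moved only modestly at a 2.2-fold higher number from compound 1 to compound 3 (0.33 log units; beyond the scatter). No step beyond the scatter is therefore expected in this assay, and the data do not settle its direction. The estimated step is a 1.2-fold higher number from compound 1 to compound 4 (0.06 log units; within the scatter). For compound 4 the expected clearance is 15 mL/min/kg, with an estimated range of 8 mL/min/kg to 30 mL/min/kg.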

Compound 4, clearance: < 9.9 mL/min/kg
Compound 4 was reported as a limit (the forecaster's own chance of this, stated with the estimate: 15%); middle value at least 1.5-fold (0.18 log units) from the limit.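

The change at this position is small and leaves the rest of the molecule as it is: in this assay, difluoromethyl in place of methyl on an oxygen on an aromatic ring gives an at least 1.3-fold lower number from compound 1 to compound 4 (0.11 log units; that floor lies within the scatter). On these data alone, compound 4 gives < 9.9 mL/min/kg, which is a limit of the assay, so only a floor on the step can be read and its true size stays unknown. The earlier steps exchanged the whole aromatic group, whereas this one isolates the methoxy and shows that the aromatic group need not be replaced to reach the same limit as compound 2, a limit that now caps the readable range of the series: the limit of < 9.9 mL/min/kg in this assay, at which 2 of the 4 values shown sit.

Compound 2 and compound 4 both stand at that limit, so no order between them can be read, and the real effect of the difluoromethyl remains hidden beneath it. Also open, as far as these compounds go, is whether trifluoromethoxy, a longer chain such as ethoxy, or an amine in the same place would stay at the limit, and whether difluoromethoxy would lower the number when carried on the 2-fluoro-4-methylphenyl group of compound 3.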